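The source may report more compounds than this note shows. Statements on the series, on what has been measured and on what is new or still open speak of the compounds shown alone.

Among the compounds with values here, compound 1, `O=S(=O)(NCCCCCCNCc1ccc(Br)cc1)c1ccccc1F`, was tested in a functional assay on MIA PaCa-2 cells (Homo sapiens) for inhibition, read by MTT assay, with a stated time of 72 h (on this read-out lower numbers stand for stronger inhibition of growth and higher numbers for weaker inhibition of growth), and gives 13300 nM, the highest number of the two measured so far. Compound 2, `O=S(=O)(NCCCNCc1ccc(Br)cc1)c1cc(C(F)(F)F)cc(C(F)(F)F)c1`, gives 2300 nM in this assay; the gap between these two values lies beyond the scatter, but the two structures differ in more than one place, so nothing beyond the two values themselves can be read from the pair. Compound 3, `O=[N+]([O-])c1ccccc1S(=O)(=O)NCCCCCCNCc1ccc(Br)cc1`, has not yet been measured. It differs from compound 1 in a single place: nitro in place of fluoro on an aromatic carbon. Within the data shown here, no measured pair shows this change on its own, and no compound carrying a nitro group has been measured, so the direction of the step is open. The expected step is a 1.3-fold lower number from compound 1 to compound 3 (0.12 log units; within the scatter), small and not clearly beyond the scatter. Compound 3 is estimated at 10000 nM, with a range from 4000 nM to 30000 nM.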

Compound 3, concentration for 50% growth inhibition: 11700 nM
Compound 3: the middle estimate sits 1.2-fold (0.07 log units) below what was measured, and the stated range covers the measured number.
By their numbers in this assay, from the lowest: compound 2; then compounds 3 and 1 (each within the scatter of the next).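

In this assay, nitro in place of fluoro on this aromatic carbon, ortho to a large group, gives a 1.1-fold lower number from compound 1 to compound 3 (0.06 log units; within the scatter), so this read-out does not separate the two compounds. Within the data shown here, this pair is the first to vary this position alone, and it shows that a group of three heavy atoms with two hydrogen-bond acceptors can replace a single fluorine with no change in growth inhibition that can be told from the scatter. No measurement at hand explains why the two groups read alike.

From the compounds shown here alone, whether an amine or a carboxylic acid at this place would also read alike remains open. Going by these compounds, it is also open whether the same swap from 2-fluorophenyl to 2-nitrophenyl would give a similar result on a shorter chain.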